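The compounds below may be only part of what the source reports. "The series", "measured", "known", "first", "only" and "open" are said of these compounds alone.

In a functional assay on MDA-MB-231 cells (Homo sapiens) for antiproliferative activity, read by XTT assay, with a stated time of 72 h (a higher number here means a weaker inhibitor, a lower number a stronger inhibitor), compound 1 `COc1ccc(-c2cc3ccccc3nc2/C=C/C(=O)c2ccco2)cc1` gives 630 nM. Compound 2 `COc1ccc(-c2cc3ccccc3nc2/C=C/C(=O)c2ccsc2)cc1` gives 1060 nM in this assay, and the step of a 1.7-fold higher number from compound 1 to compound 2 (0.23 log units; within the scatter) shows that the exchange of the furan-2-yl group for a thiophen-3-yl group on the carbonyl carbon leaves the result within the scatter. Compound 3 `COc1ccc(-c2cc3ccccc3nc2/C=C/C(=O)c2sccc2N)cc1` reaches only a limit in this assay, > 10000 nM, so for compound 3 a limit is known and no number. The steps of an at least 15-fold higher number from compound 1 to compound 3 (1.20 log units; beyond the scatter) and an at least 9.4-fold higher number from compound 2 to compound 3 (0.97 log units; beyond the scatter) are therefore read against (the limit of > 10000 nM in this assay, at which 1 of the 3 values shown sits), and both lie beyond the scatter.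

Compound 4 `COc1ccc(-c2cc3ccccc3nc2/C=C/C(=O)c2cnc(N)nc2C)cc1` has not yet been measured. It differs from compound 3 in one place: 2-amino-4-methylpyrimidin-5-yl in place of 3-aminothiophen-2-yl on a carbonyl carbon. Going by the values given here, no measured step places a six-membered ring on the carbonyl carbon, so the only steps that bear on this change are the two that lead to compound 3, and both record a large loss on entering the 3-aminothiophen-2-yl group. Whether the 2-amino-4-methylpyrimidin-5-yl group recovers part of that loss cannot be read from the measured steps. The expected step is an at least 1.6-fold lower number from compound 3 to compound 4 (0.22 log units; that floor lies within the scatter), a modest move toward a lower number with wide uncertainty. For compound 4 the estimate in this assay is 6000 nM, between 1500 nM and 20000 nM.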

Compound 4, half-maximal inhibitory concentration: > 10000 nM
Compound 4: no number, only a limit; the forecaster's own chance of this, stated with the estimate: 45%; middle value at least 1.6-fold (0.22 log units) from the limit.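

In this assay compound 4 reaches only a limit, > 10000 nM. Measured against the furan-2-yl and thiophen-3-yl groups on the carbonyl carbon, the 2-amino-4-methylpyrimidin-5-yl group shows an at least 9.4-fold higher number from compound 2 to compound 4 (0.97 log units; beyond the scatter) and an at least 15-fold higher number from compound 1 to compound 4 (1.20 log units; beyond the scatter), so the large loss first seen with the 3-aminothiophen-2-yl group is not confined to that one group and also appears with a six-membered aromatic ring. Compound 3 also stands at a limit, so the step between it and compound 4 cannot be read and neither group can be ranked above the other: the limit of > 10000 nM in this assay, at which 2 of the 4 values shown sit.

Both groups that end at a limit carry an amine and both groups with a readable value carry none, but the ring changes along with the amine, so these compounds leave open whether the amine itself accounts for the loss. A thiophen-2-yl group without the amine, or a plain phenyl ring and its amino-substituted counterpart, on the same carbonyl carbon would separate the effect of the amine from that of the ring carrying it.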